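Swapping Chloro for Trifluoromethyl on Compound 1

The compounds below may be only part of what the source reports. "The series", "measured", "known", "first", "only" and "open" are said of these compounds alone.

Compound 1 `Cc1[nH]n(-c2nc3cc(Cl)ccc3[nH]2)c(=O)c1Cc1ccccc1`: 87%
Compound 2 `Cc1ccc2[nH]c(-n3[nH]c(C)c(C)c3=O)nc2c1`: 69%
Compound 3 `Cc1nn(-c2nc3ccccc3[nH]2)c(O)c1Cc1ccccc1`: 90%

All three were tested in a functional assay on DU-145 cells (Homo sapiens) for antiproliferative activity, read by WST assay, with a stated time of 7 days, tested at 10 uM; a lower number here means a weaker effect, a higher number a stronger effect of the compound at the concentration tested. Compound 1 stands second highest of the three numbers, but its nearest neighbour, compound 3, sits within the usual scatter, so the two cannot be told apart; compound 2 lies beyond the scatter, lower. The untested compound 4 `Cc1[nH]n(-c2nc3cc(C(F)(F)F)ccc3[nH]2)c(=O)c1Cc1ccccc1` differs from compound 1 by trifluoromethyl in place of chloro on an aromatic carbon. Within the data shown here, no measured pair shows this exact change, so its size cannot be read from the data. The expected step is a number 5 percentage points lower from compound 1 to compound 4 (within the scatter), small and within the scatter, with no clear direction. Compound 4 is therefore estimated at 82%, with a range from 60% to 95%.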

Compound 4, a percentage reported as inhibition, at one concentration (the size of the read-out at that concentration, not a potency): 92%
For compound 4 the middle estimate is 10 percentage points below the measured one; low and high end bracket the measured number.
By their numbers in this assay, from the lowest: compound 2; then compounds 1, 3 and 4 (each within the scatter of the next).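

In this assay, trifluoromethyl in place of chloro on this aromatic carbon gives a number 5 percentage points higher from compound 1 to compound 4 (within the scatter). Among these compounds, this is the first direct comparison at this position: a group with more heavy atoms than chloro fits here, and the two compounds cannot be told apart. No measurement shown explains why they read alike. From the compounds shown here alone, whether an amine or a carboxylic acid at this position would keep the effect remains open. A single concentration also shows the size of an effect rather than a potency, so compound 1 and compound 4 could still differ at other concentrations.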